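Side-chain amine change from compound 2 to compound 3

This account rests on a few compounds, and the source may have more. Where it says the series, first, only, none or still open, it means among the compounds named here.

Measured so far in an ADME assay on L6 cells (Rattus norvegicus) for cytotoxicity; a lower number here means a stronger inhibitor, a higher number a weaker inhibitor
- compound 1 `O=C(CN1CCCC1)OC1CC2(N3CCCC3)CC(c3ccccc3)C1C(c1ccccc1)C2` gives 42900 nM
- compound 2 `O=C(CN1CCCCC1)OC1CC2(N3CCCC3)CC(c3ccccc3)C1C(c1ccccc1)C2` gives 14200 nM

Compound 2 holds the lower of the two numbers, and the gap to compound 1 lies beyond the scatter. Next in the series is compound 3 `CCN(CC)CCC(=O)OC1CC2(N3CCCC3)CC(c3ccccc3)C1C(c1ccccc1)C2`, still without a measurement. Its difference from compound 2 is (diethylamino)methyl in place of piperidin-1-yl on a saturated chain carbon bound to a carbonyl carbon. Cut one bond further out, the same difference reads (piperidin-1-yl)methyl to 2-(diethylamino)ethyl.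

For the measured compounds named here, one measured step bears on this, a 3.0-fold lower number from compound 1 to compound 2 (0.48 log units; beyond the scatter), which is modest and made at the same place. That step replaces one ring with another, whereas the group entering compound 3 has no ring, so the data fix no direction. In this assay a change no larger than that modest step is therefore expected. The expected step is a 1.2-fold higher number from compound 2 to compound 3 (0.08 log units; within the scatter), which is small and uncertain in sign. The estimate for compound 3 is 17000 nM, with an expected range from 6000 nM to 42000 nM for the measurement.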

Compound 3, half-maximal inhibitory concentration: 19200 nM
For compound 3 the middle estimate is 1.1-fold (0.05 log units) below the measured one, within the range that was stated.
By their numbers in this assay, from the lowest: compounds 2 and 3 (each within the scatter of the next); then compound 1.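

In this assay, the ring of piperidin-1-yl can give way to the open-chain (diethylamino)methyl group with no change beyond the scatter, a 1.4-fold higher number from compound 2 to compound 3 (0.13 log units; within the scatter), so on this saturated chain carbon bound to a carbonyl carbon, a ring is not required to stay level with compound 2. The same open-chain group set against pyrrolidin-1-yl gives a 2.2-fold lower number from compound 1 to compound 3 (0.35 log units; beyond the scatter), which is modest, so among the three compounds, compound 1 alone stands apart, while compound 2 and compound 3 form one level despite their different amine shapes. No measured information on any property of these groups bears on these steps, so the result remains a description of the numbers only.

On these data alone, it remains open whether that level extends to a morpholin-4-yl group, to a primary amine, or to a longer chain carrying the diethylamino group. The compounds shown also leave open whether a carboxylic acid at this place, with no amine in the side chain, would keep the number near that of compound 2 and compound 3.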